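From butyl to 4-methylphenyl on the shared core

This account rests on a few compounds, and the source may have more. Where it says the series, first, only, none or still open, it means among the compounds named here.

In a functional assay on HT-29 cells (Homo sapiens) for cytotoxicity, read by MTT assay, with a stated time of 48 h (on this read-out higher numbers stand for weaker inhibition and lower numbers for stronger inhibition), compound 1 `CCCCC1C(C(=O)OCC)=C(C)NC(C)=C1C(=O)OCC` is reported as "not active" (no number reported) without a number. Within the data shown here, compound 2 `CCCCC1C(C(=O)OC)=C(C)NC(C)=C1C(=O)OC` gives 500000 nM and holds the only number, so it has no numerical comparator. Compound 3 `COC(=O)C1=C(C)NC(C)=C(C(=O)OC)C1c1ccc(C)cc1` differs through 4-methylphenyl in place of butyl on a saturated ring carbon with 4-methylphenyl in place of butyl on a saturated ring carbon. Among the measured compounds shown here, no measured step is available to size this change. The estimated 2.5-fold lower number from compound 2 to compound 3 (0.40 log units; beyond the scatter) in this assay is expected to be modest and toward stronger inhibition. Compound 3 is expected at 200000 nM within an estimated range from 50000 nM to 600000 nM in this assay.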

Compound 3, half-maximal inhibitory concentration: "not active" (no number reported)
Compound 3: no number reported, and the estimate cannot be compared.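

Compound 3 carries no number, so no step from compound 2 to it can be read, and no measurement here points to a cause. The compounds shown leave open how far 4-methylphenyl in place of butyl shifts the read-out in this assay on the shared core.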